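The source may hold more compounds than are shown below. What is called first, only, known or untested is meant among the compounds shown, and "the series" means these compounds.

Measured so far in an ADME assay on HCT-116 cells (Homo sapiens) for cytotoxicity, read by MTT assay; a lower number here means that less compound is tolerated, a higher number that more compound is tolerated 
Compound 1 `Cc1nc(-c2cccnc2)sc1-c1nnc(-c2ccccc2Cl)o1` gives > 100 ug/mL 
Compound 2 `Cc1nc(-c2cccnc2)sc1-c1nnc(-c2ccc([N+](=O)[O-])cc2)o1` gives > 100 ug/mL 
Compound 3 `Cc1ccccc1-c1nnc(-c2sc(-c3cccnc3)nc2C)o1` gives > 100 ug/mL 

In this assay compound 2 gives > 100 ug/mL as a limit, not a number. The three compounds share this ceiling, seen in the limit of > 100 ug/mL in this assay, at which 3 of the 3 values shown sit, and so no true value is known for any of them. Compound 4 `Cc1nc(-c2cccnc2)sc1-c1nnc(-c2ccc(O)cc2)o1` differs from compound 2 by hydroxy in place of nitro on an aromatic carbon and thus has hydroxy in place of nitro. Among the measured compounds shown here, the only measured step is a step that the two limits leave unreadable from compound 1 to compound 3 and it concerns a different group, so it gives no size to carry over. No step beyond the scatter can be foreseen in either direction, and what is expected is a step that the limit leaves unreadable from compound 2 to compound 4 in this assay on this thin evidence. Compound 4 is estimated at 130 ug/mL with an expected range of 50 ug/mL to 300 ug/mL and may well return only a limit.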

Compound 4, half-maximal cytotoxic concentration: > 100 ug/mL
Compound 4 was reported as a limit; the forecaster's own chance of this, stated with the estimate: 70%; the middle value is on the limit's open side.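

Compound 4 also gives only a limit, so its steps from compound 1, compound 2 and compound 3 cannot be read, because all four compounds share one ceiling: the limit of > 100 ug/mL in this assay, at which 4 of the 4 values shown sit. From the compounds shown here alone, the true values of all four compounds in this assay, and any differences between them, remain open.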